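What a smaller ring may do to compound 3

This account rests on a few compounds, and the source may have more. Where it says the series, first, only, none or still open, it means among the compounds named here.

In a toxicity assay on L02 cells (Homo sapiens) for cytotoxicity, read by MTT assay, with a stated time of 72 h (a lower number here means a stronger inhibitor, a higher number a weaker inhibitor), three compounds built on a shared core have been measured. Compound 1 `O=C1c2c[n+]([O-])c3ccccc3c2C(=O)c2c1c1ccccc1n2Cc1cn(C[C@H](O)CO)nn1` gives 1130 nM, compound 2 `O=C1c2c[n+]([O-])c3ccccc3c2C(=O)c2c1c1ccccc1n2CCCCN1CCNCC1` gives 1380 nM, and compound 3 `CCCCN1CCN(CCCCn2c3c(c4ccccc42)C(=O)c2c[n+]([O-])c4ccccc4c2C3=O)CC1` gives 5690 nM. Compound 3 has the highest number of the three, so it is the weakest inhibitor of these cells in the set.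

The next structure is compound 4 `O=C1c2c[n+]([O-])c3ccccc3c2C(=O)c2c1c1ccccc1n2CCCCN1CCCCC1`, where piperidin-1-yl takes the place of 4-butylpiperazin-1-yl: piperidin-1-yl in place of 4-butylpiperazin-1-yl on a saturated chain carbon, four bonds along the chain from an aromatic nitrogen. The core and the chain stay as they are, and only the ring at the end of the chain and what it carries change.

Two measured steps offer some guidance. Exchanging whole side chains gave a 1.2-fold higher number from compound 1 to compound 2 (0.09 log units; within the scatter), which is too small to read anything into. Putting butyl in place of hydrogen on an amine nitrogen in a ring gave a 4.1-fold higher number from compound 2 to compound 3 (0.62 log units; beyond the scatter), the clearer signal. Within the data shown here, compound 4 carries no such butyl, so part of that rise is expected to be undone, although no measured pair tests this ring swap directly. The estimated step is modest, toward a lower number: a 2.4-fold lower number from compound 3 to compound 4 (0.37 log units; beyond the scatter). For compound 4 the expected value is 2400 nM, with an estimated range from 1000 nM to 5500 nM.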

Compound 4, half-maximal inhibitory concentration: 610 nM
Beside the measured number, compound 4's estimate is 3.9-fold (0.59 log units) above it, outside the stated range (below it).
By their numbers in this assay, from the lowest: compounds 4, 1 and 2 (each within the scatter of the next, the first and the last beyond it); then compound 3.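

Compounds 2 and 3 showed only that adding butyl to the piperazine ring raises the number in this assay; the full change to piperidin-1-yl gives a much larger fall (a 9.3-fold lower number from compound 3 to compound 4 (0.97 log units; beyond the scatter)) than the rise seen on adding butyl (a 4.1-fold higher number from compound 2 to compound 3 (0.62 log units; beyond the scatter)). The butyl therefore does not tell the whole story, since swapping piperazin-1-yl for piperidin-1-yl, with no butyl on either ring, still moves the number beyond the scatter (a 2.3-fold lower number from compound 2 to compound 4 (0.35 log units; beyond the scatter)), so the make-up of the ring itself matters at this place on the chain. The side chains of compound 1 and compound 4 differ far more in appearance, yet their numbers remain within the scatter of each other (a 1.9-fold lower number from compound 1 to compound 4 (0.27 log units; within the scatter)), so a piperidine-bearing chain does not separate from the triazole-bearing diol.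

A morpholine ring, with an oxygen in place of the second ring nitrogen, or a shorter chain carrying the piperidin-1-yl group, would test how far this trend extends. Nothing available here offers an explanation for these shifts.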